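Fused ring with two methyls on the chloropyridine core

A few compounds are considered here, and "the series" means these few. Any claim that something is new, unique, unknown or untested is made for them only; others in the source may bear on it.

Measured so far:
Compound 1 `CC(=O)N[C@@H]1CCC[C@H](C(=O)Nc2cc(-c3cnn(C)c3C)c(Cl)cn2)C1` gives 10 uL/min in an ADME assay on cells (Hepatocyte, Rattus norvegicus) for metabolic stability, using equilibrium dialysis; a higher number here means faster removal of the compound, a lower number slower removal.
Compound 2 `CC(=O)N[C@@H]1CCC[C@H](C(=O)Nc2cc(-c3cnn4c3CCC4)c(Cl)cn2)C1` gives 72 uL/min in this assay.
Compound 3 `CC(=O)N[C@@H]1CCC[C@H](C(=O)Nc2cc(-c3cnn4c3CC(C)(C)C4)ccn2)C1` gives 45 uL/min in this assay.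

Going by the values given here, compound 2 has the highest number of the three; compound 3 lies within the scatter of it, while compound 1 lies beyond it, with a 7.2-fold higher number from compound 1 to compound 2 (0.86 log units; beyond the scatter) the only step that is measured in one place. Compound 4 `CC(=O)N[C@@H]1CCC[C@H](C(=O)Nc2cc(-c3cnn4c3CC(C)(C)C4)c(Cl)cn2)C1` differs from compound 2 as follows: a group of 10 heavy atoms (8 carbon, 2 nitrogen; one five-membered non-aromatic ring with 1 hetero atom, one five-membered aromatic ring with 2 hetero atoms) in place of a group of 8 heavy atoms (6 carbon, 2 nitrogen; one five-membered non-aromatic ring with 1 hetero atom, one five-membered aromatic ring with 2 hetero atoms), on an aromatic carbon. Among the compounds with values here, no measured step bears directly on this change; the step from compound 1 to compound 2 touches the same position but adds a different group. Compound 3 carries the same entering group without the chloro and shows a number within the scatter of compound 2. For compound 4 a step of a 1.3-fold lower number from compound 2 to compound 4 (0.12 log units; within the scatter) is therefore expected, with no clear direction beyond the scatter. Compound 4 is estimated at 55 uL/min, within 25 uL/min to 120 uL/min.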

Compound 4, intrinsic clearance in a liver preparation (reported as CLH), per the amount of preparation that the assay uses: 73 uL/min
Estimate against measurement, compound 4: 1.3-fold (0.12 log units) below, and the stated range covers the measured number.
By their numbers in this assay, from the lowest: compound 1; then compounds 3, 2 and 4 (each within the scatter of the next).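

On the aromatic carbon carrying the fused ring, the group of 10 heavy atoms in place of the group of 8 heavy atoms makes no clear difference in this assay, with a 1.0-fold higher number from compound 2 to compound 4 (0.01 log units; within the scatter). Chloro in place of hydrogen, with the group of 10 heavy atoms present in both compounds, also stays small, with a 1.6-fold higher number from compound 3 to compound 4 (0.21 log units; within the scatter). The gap to the unfused group remains, with a 7.3-fold higher number from compound 1 to compound 4 (0.86 log units; beyond the scatter).

Nothing available here accounts for that gap. From the compounds shown here alone, whether a hydroxyl or an amine on the non-aromatic ring would bring the number closer to that of compound 1 remains open.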